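Bromo to hydroxy: an open step for compound 3

The compounds below may be only part of what the source reports. "The series", "measured", "known", "first", "only" and "open" are said of these compounds alone.

Measured so far in a functional assay on HepG2 cells (Homo sapiens) for cytotoxicity, read by MTT assay, with a stated time of 72 h; on this read-out lower numbers stand for stronger inhibition and higher numbers for weaker inhibition:
- Compound 1 `O=C(N/N=C/c1ccc(F)cc1)Nc1cc2c(Nc3ccc(F)c(Cl)c3)ncnc2cc1O[C@H]1CCOC1`: "not active" (no number reported)
- Compound 2 `O=C(N/N=C/c1ccc(O)c(Br)c1)Nc1cc2c(Nc3ccc(F)c(Cl)c3)ncnc2cc1O[C@H]1CCOC1`: 660 nM

Among the measured compounds shown here, compound 2 holds the only number in this assay so far, while compound 1 gave none. Compound 3 `O=C(N/N=C/c1ccc(O)cc1O)Nc1cc2c(Nc3ccc(F)c(Cl)c3)ncnc2cc1O[C@H]1CCOC1` awaits measurement and comes from compound 2 through one change 2,4-dihydroxyphenyl in place of 3-bromo-4-hydroxyphenyl on a carbon with a double bond to nitrogen on a carbon with a double bond to nitrogen. For the measured compounds named here, no measured step between compounds differing in one place is available, so only a modest shift toward weaker inhibition is expected, possibly within the usual scatter. The estimated change is a 1.7-fold higher number from compound 2 to compound 3 (0.22 log units; within the scatter) and remains an expectation. For compound 3 the estimated value is 1100 nM with an expected range from 250 nM to 5000 nM in this read-out.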

Compound 3, half-maximal inhibitory concentration: 4530 nM
The estimate for compound 3 lay 4.1-fold (0.61 log units) below the measured number, and the stated range covers the measured number.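

In this assay, 2,4-dihydroxyphenyl in place of 3-bromo-4-hydroxyphenyl on a carbon with a double bond to nitrogen gives a 6.9-fold higher number from compound 2 to compound 3 (0.84 log units; beyond the scatter) and so weakens inhibition beyond the scatter. Among the compounds shown here, this is the only readable step at this position, and it shows that the number responds to the group carried there. No available measurement accounts for the shift.

From the compounds shown here alone, the step swaps two substituents at once, so the separate shares of the bromine and the added hydroxyl remain open. So does the effect of an amine or a methoxy group on this ring.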